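Inverting one ring stereocentre of compound 1

The compounds below may be only part of what the source reports. "The series", "measured", "known", "first", "only" and "open" are said of these compounds alone.

compound 1 `COc1cc([C@@H]2C[C@@]2(CO)C(=O)Nc2ccccc2)cc(OC)c1OC` gives 86400 nM
compound 2 `COc1cc([C@@H]2C[C@]2(CO)C(=O)NCc2ccc(C)cc2)cc(OC)c1OC` gives 17400 nM
compound 3 `CCOC(=O)[C@]1(C(=O)Nc2ccccc2)C[C@@H]1c1cc(OC)c(OC)c(OC)c1` gives only the limit > 100000 nM

In a functional assay on HeLa cells (Homo sapiens) for cytotoxicity, read by MTT assay, with a stated time of 48 h (on this read-out higher numbers stand for weaker inhibition and lower numbers for stronger inhibition), compound 1 gives 86400 nM as the higher of the two actual numbers, and compound 2 gives 17400 nM as the lower, a gap beyond the usual scatter. Compound 3 gives > 100000 nM and this is a limit, not a number.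

The next compound to be measured is compound 4 `COc1cc([C@H]2C[C@@]2(CO)C(=O)Nc2ccccc2)cc(OC)c1OC` and it relates to compound 1 as follows: the two compounds have the same atoms and bonds and differ only in configuration as drawn: 1 of 2 stereo elements differ; a stereocentre at a saturated ring carbon is drawn S in compound 1 and R in compound 4 and so a stereocentre at a saturated ring carbon is drawn S in compound 1 and R in compound 4.

Among the compounds with values here, no measured pair in this set shows what a change of configuration alone does. Within the data shown here, compound 2 differs from compound 1 in more than one place, so its value gives no size for this step. The expectation therefore rests on compound 1 itself, which at 86400 nM already stands high on the scale. A step no larger than the scatter is expected, leaning if anything towards a lower number.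

The expected step of a 1.6-fold lower number from compound 1 to compound 4 (0.20 log units; within the scatter) would stay within the scatter. For compound 4 the estimated value is 55000 nM with an expected range from 20000 nM as the lower end to 100000 nM as the upper end.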

Compound 4, half-maximal inhibitory concentration: > 100000 nM
Compound 4: a limit, no number; the forecaster's own chance of this, stated with the estimate: 25%; at least 1.8-fold (0.25 log units) between middle value and limit.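

Within the data shown here, the pair of compound 1 and compound 4 is the first in this set to isolate configuration, and inverting the stereocentre at a saturated ring carbon brought no measurable gain in inhibition. In this assay, compound 4 gives > 100000 nM, which is a limit of the assay and not a number. The step can therefore be read only as a floor, an at least 1.1-fold higher number from compound 1 to compound 4 (0.06 log units; that floor lies within the scatter), so the change may be small or much larger, but the drawn S configuration of compound 1 is the only one of the two that yields an actual number, and the comparison isolates this one change: the fact that compounds 1 and 4 differ only in the configuration as drawn.

Going by these compounds, how far compound 4 really lies from compound 1 stays unknown, since the reading stops at the top of the tested range: the limit of > 100000 nM in this assay, at which 2 of the 4 values shown sit. The compounds shown also leave open whether this inversion would act in the same way with a different amide, and what a carboxylic acid or an amine in place of the alcohol would do in either configuration.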